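Working notes: methoxy in place of tert-butyl

This account rests on a few compounds, and the source may have more. Where it says the series, first, only, none or still open, it means among the compounds named here.

In a functional assay (aorta) with Oryctolagus cuniculus as the target (on this read-out lower numbers stand for tighter binding and higher numbers for weaker binding), compound 3 (`CC(C)(C)c1ccc(OCCCN2CCC(C(c3ccc(F)cc3)c3ccc(F)cc3)CC2)cc1`) gives 1 nM. This is within the scatter of compound 1 (`Fc1ccc(OCCCN2CCC(C(c3ccc(F)cc3)c3ccc(F)cc3)CC2)cc1`) at 1.26 nM and compound 2 (`Fc1ccc(C(c2ccc(F)cc2)C2CCN(CCCOc3ccc(Br)cc3)CC2)cc1`) at 1.59 nM.

Compound 4 (`COc1ccc(OCCCN2CCC(C(c3ccc(F)cc3)c3ccc(F)cc3)CC2)cc1`) carries methoxy in place of tert-butyl on an aromatic carbon, para to a large group: methoxy in place of tert-butyl on an aromatic carbon.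

Three measured steps exchange the group at this place: a 1.3-fold higher number from compound 1 to compound 2 (0.10 log units; within the scatter), a 1.3-fold lower number from compound 1 to compound 3 (0.10 log units; within the scatter) and a 1.6-fold lower number from compound 2 to compound 3 (0.20 log units; within the scatter). All three lie within the scatter. Going by the values given here, no methoxy compound has been measured yet, so this read rests on fluoro, bromo and tert-butyl alone, and no step beyond the scatter is expected in this assay.

The estimated step is a 1.6-fold higher number from compound 3 to compound 4 (0.20 log units; within the scatter).

Compound 4 is expected at 1.6 nM, with an estimated range of 0.6 nM to 4 nM.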

Compound 4, dissociation constant: 2.51 nM
Compound 4: middle estimate off by 1.6-fold (0.20 log units), on the low side, within the range that was stated.
By their numbers in this assay, from the lowest: compounds 3, 1, 2 and 4 (each within the scatter of the next, the first and the last beyond it).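

In this assay this position gives its first step beyond the scatter, a 2.5-fold higher number from compound 3 to compound 4 (0.40 log units; beyond the scatter) for methoxy in place of tert-butyl on an aromatic carbon. Against the fluoro and bromo compounds, methoxy stays within the scatter, with a 2.0-fold higher number from compound 1 to compound 4 (0.30 log units; within the scatter) and a 1.6-fold higher number from compound 2 to compound 4 (0.20 log units; within the scatter) as the two steps, so the separation holds for the tert-butyl pair only. Nothing measured here explains this step.

Still open, as far as these compounds go, is how an amine or a carboxylic acid at this place would read in this assay. Also open, from the compounds shown here alone, is whether a longer alkoxy chain would stay with methoxy or with tert-butyl.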